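This account rests on a few compounds, and the source may have more. Where it says the series, first, only, none or still open, it means among the compounds named here.

Compound 1 `Cc1cc(Nc2cc(-c3ccccc3)[nH]n2)n2ncnc2n1` is the starting point. In an ADME assay on GES1 cells (Homo sapiens) for inhibition, read by MTT assay, with a stated time of 72 h (a higher number here means a weaker inhibitor, a lower number a stronger inhibitor), compound 1 gives > 50000 nM, which is a limit of the assay rather than a number. Compound 2 `CCCCCc1c(C)nc2nc(SCc3ccc(Cl)cc3)nn2c1Nc1cc(-c2ccccc2)[nH]n1` is a more heavily substituted relative. In this assay compound 2 gives > 50000 nM, again a limit. Both measured values share (the limit of > 50000 nM in this assay, at which 2 of the 2 values shown sit). Compound 3 `Cc1cc(Nc2cc(-c3ccccc3)[nH]n2)n2nc(SCc3nc4ccccc4[nH]3)nc2n1` differs from compound 1 by ((1H-benzimidazol-2-yl)methyl)sulfanyl in place of hydrogen on an aromatic carbon. Within the data shown here, no measured step is available for this change, so in this assay the shift is expected to be none beyond the scatter, estimated as a number no higher from compound 1 to compound 3 (the limit leaves the size open). Compound 3 is expected to give about 50000 nM, within 20000 nM to 100000 nM.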

Compound 3, half-maximal inhibitory concentration: 27800 nM
The estimate for compound 3 lay 1.8-fold (0.25 log units) above the measured number, within the range that was stated.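

Among these compounds, at the aromatic carbon between two ring nitrogen atoms, ((1H-benzimidazol-2-yl)methyl)sulfanyl in place of hydrogen gives a measured number in this assay, where the earlier compounds stay at a limit: the limit of > 50000 nM in this assay, at which 2 of the 3 values shown sit. The change brings an at least 1.7-fold lower number from compound 1 to compound 3 (0.25 log units; that floor lies within the scatter). Going by these compounds, compound 1 holds only a limit, and the true size of this step stays open.

The compounds shown leave open whether a smaller group at this carbon, such as an amine or a methylsulfanyl, would also give a measured number. They also leave open what a carboxylic acid on the benzimidazole part would do.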